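A few compounds are considered here, and "the series" means these few. Any claim that something is new, unique, unknown or untested is made for them only; others in the source may bear on it.

Compound 1 `CCO/C(O)=C1\C(C)=NC(C)=C([N+](=O)[O-])C1c1ccncc1`: 6460 nM
Compound 2 `CC1=NC(C)=C([N+](=O)[O-])C(c2ccccn2)/C1=C(\O)OC1CCCC1`: 19800 nM
Compound 3 `CC1=NC(C)=C([N+](=O)[O-])C(c2cccnc2)/C1=C(\O)OC1CCCC1`: 3280 nM

These three values come from a functional assay (cardiac atrium) for agonist activity, with Cavia porcellus as the target; on this read-out lower numbers stand for an effect already at smaller amounts and higher numbers for an effect only at larger amounts of compound. Within the data shown here, compound 2 gives the highest number of the three; compound 1 stands nearest to it and compound 3 furthest, and the only step between two compounds that differ in one place is a 6.0-fold lower number from compound 2 to compound 3 (0.78 log units; beyond the scatter), which swaps the aromatic group on the saturated ring carbon. Compound 4 `CC1=NC(C)=C([N+](=O)[O-])C(c2ccccn2)/C1=C(\O)OC(C)(C)C` differs from compound 2 elsewhere: tert-butyl in place of cyclopentyl on an oxygen on an unsaturated carbon. Among the measured compounds shown here, no measured step bears on this change; the step from compound 2 to compound 3 concerns another place and gives no guide to its size. Compound 4 is therefore expected to stay close to compound 2, with a 1.0-fold higher number from compound 2 to compound 4 (0.00 log units; within the scatter) amounting to no step beyond the scatter. Compound 4 is estimated at 20000 nM, between 6000 nM and 65000 nM.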

Compound 4, half-maximal effective concentration: 1810000 nM
For compound 4 the middle estimate is 91-fold (1.96 log units) below the measured one; the whole stated range lies below it.
By their numbers in this assay, from the lowest: compounds 3 and 1 (each within the scatter of the next); then compound 2; then compound 4.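

In this assay, the group on the oxygen proves to be a sensitive place: tert-butyl in place of cyclopentyl gives a 91-fold higher number from compound 2 to compound 4 (1.96 log units; beyond the scatter), a larger change than a 6.0-fold lower number from compound 2 to compound 3 (0.78 log units; beyond the scatter). Both groups are carbon only, with no hydrogen-bond donors or acceptors and no net charge, yet the swap still moves the number strongly. Nothing measured here explains the size of this step.

On these data alone, whether the ring or the branching matters remains open, and a cyclohexyl group or a straight butyl chain on that oxygen would help separate them. As far as these compounds go, whether tert-butyl acts the same way alongside pyridin-3-yl also remains open.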